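Turning a Ring Stereocentre in a Kinase Inhibitor Pair

The source may report more compounds than this note shows. Statements on the series, on what has been measured and on what is new or still open speak of the compounds shown alone.

The measured compounds:
compound 1, `CC(=O)Nc1cc(Cl)cc(Nc2nc(N[C@H]3CCCC[C@H]3N)nc3c2ncn3C(C)C)c1`, gives > 1000 nM in an assay on isolated protein for inhibition of dual specificity protein kinase CLK3 (Homo sapiens), read by scintillation counting and 33P incorporation, with a stated time of 40 min, in the presence of a further agent that is not named here; on this read-out lower numbers stand for stronger inhibition and higher numbers for weaker inhibition
compound 2, `CC(C)n1cnc2c(Nc3cc(N)cc(Cl)c3)nc(N[C@H]3CCNC3)nc21`, gives > 1000 nM in this assay

The value of compound 1 is a limit of the assay, not a number. The value of compound 2 is likewise only a limit. Where compound 2 stands can therefore be said only loosely: it shows no inhibition strong enough to be resolved, and compound 1 behaves the same way, so that both results sit at the limit of > 1000 nM in this assay, at which 2 of the 2 values shown sit. Going by the values given here, no step between two measured compounds exists here, and two limits give no pattern to build on.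

Compound 3, `CC(C)n1cnc2c(Nc3cc(N)cc(Cl)c3)nc(N[C@@H]3CCNC3)nc21`, has not yet been measured. It differs from compound 2 in one respect: the two compounds have the same atoms and bonds and differ only in configuration as drawn: 1 of 1 stereo elements differ; a stereocentre at a saturated ring carbon is drawn S in compound 2 and R in compound 3. Because compound 2 gives > 1000 nM, only a weak anchor is available for the change. No step beyond the usual scatter is expected in either direction, and the estimate for compound 3 is most likely itself a limit. Compound 3 is expected to give 3000 nM, with a range from 800 nM to 15000 nM. The expected step that the limit leaves unreadable from compound 2 to compound 3 is estimated to stay within the scatter.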

Compound 3, half-maximal inhibitory concentration: > 1000 nM
Compound 3 ended at the assay's limit; the forecaster's own chance of this, stated with the estimate: 85%; the middle value does not contradict the limit.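

Compound 3 gives > 1000 nM in this assay, a limit of the assay and not a number. As far as these compounds go, compound 2 also sits at a limit, so no step can be read between compound 2 and compound 3, whose configurations are drawn S and R. What remains open is how strongly either compound inhibits, and whether the two configurations differ at all.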